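Hydroxyphenyl isomers on a shared core: no topoisomerase inhibition

The source may report more compounds than this note shows. Statements on the series, on what has been measured and on what is new or still open speak of the compounds shown alone.

Of the compounds shown here, two have been measured. Compound 1, `Oc1ccc(-c2cc(-c3ccccc3O)cc(-c3cccc(O)c3)n2)cc1`, gives 0% in an assay on isolated protein for inhibition of DNA topoisomerase 1 (Homo sapiens), with a stated time of 30 min, tested at 100 uM; a lower number here means less inhibition, a higher number more inhibition at the concentration tested (going by the name of the read-out). Compound 2, `Oc1ccc(-c2cc(-c3cccc(O)c3)cc(-c3ccc(O)cc3)n2)cc1`, gives 0% in this assay, level with compound 1 at the digits reported, the two lying within the usual scatter of each other. Neither compound shows measurable inhibition at the concentration tested. Compound 3, `Oc1ccc(-c2cc(-c3ccccc3O)cc(-c3ccc(O)cc3)n2)cc1`, has not yet been measured in this assay. It has the same atoms as compound 2, joined differently: 2-hydroxyphenyl in place of 3-hydroxyphenyl on an aromatic carbon. The change is the placement of the hydroxyl on one of the three hydroxyphenyl groups, on an aromatic carbon of the shared core. Compound 1 already carries a 2-hydroxyphenyl group and gives no inhibition, so the series offers no sign that this placement matters. The step from compound 2 to compound 3 is expected to be none beyond the scatter, no change at the digits printed from compound 2 to compound 3 (within the scatter). For compound 3 the estimate in this assay is 0%, with a range from 0% to 10%.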

Compound 3, a percentage reported as inhibition, at one concentration (the size of the read-out at that concentration, not a potency): 0.4%
Estimate against measurement, compound 3: 0.4 percentage points below; measured number inside the range.
By their numbers in this assay, from the lowest: compounds 1, 2 and 3 (each within the scatter of the next).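

Within the data shown here, on the aromatic carbon opposite the ring nitrogen, with two 4-hydroxyphenyl groups on the shared core, 2-hydroxyphenyl in place of 3-hydroxyphenyl gives a number 0.4 percentage points higher from compound 2 to compound 3 (within the scatter) in this assay, the first direct comparison of two hydroxyl placements at this position. With 2-hydroxyphenyl held on that carbon, 4-hydroxyphenyl in place of 3-hydroxyphenyl on another aromatic carbon gives a number 0.4 percentage points higher from compound 1 to compound 3 (within the scatter), so moving the hydroxyl on either of these two groups leaves the read-out within the scatter. No supporting measurement is available to account for this result.

All three compounds read close to nil in this assay at a single concentration, so these data cannot show whether hydroxyl placement would matter in a compound with clear inhibition. Also open, as far as these compounds go, is whether an amine or a carboxylic acid in place of one of the hydroxyl groups, or a longer chain on one of the phenyl groups, would give any inhibition in this assay.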